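The source may hold more compounds than are shown below. What is called first, only, known or untested is meant among the compounds shown, and "the series" means these compounds.

Working notes on the series. In a functional assay on HeLa cells (Homo sapiens) for cytotoxicity, read by resazurin assay, with a stated time of 72 h (on this read-out higher numbers stand for weaker inhibition and lower numbers for stronger inhibition), compound 3 (`COc1ccc(C(=O)CSC(=S)SCCNC(C)=O)cc1`) gives 11100 nM, within the scatter of compound 2 (`CCNC(=S)SCC(=O)c1ccc(OC)cc1`) at 7800 nM, while compound 1 (`CCSC(=S)SCC(=O)c1ccc(OC)cc1`) gives 1960 nM. Compound 4 (`COCCSC(=S)SCC(=O)c1ccc(OC)cc1`) has methoxy in place of acetamido on a saturated chain carbon, two bonds along the chain from a sulfur. Methoxy at this place is unmeasured. The closest evidence is a 5.7-fold higher number from compound 1 to compound 3 (0.75 log units; beyond the scatter), a modest step beyond the scatter for acetamido in place of hydrogen at the same place. a 1.4-fold higher number from compound 2 to compound 3 (0.15 log units; within the scatter) adds little, lying within the scatter. Removing acetamido may recover part of the step from compound 1, so a modest move to a lower number is expected in this assay, a 3.2-fold lower number from compound 3 to compound 4 (0.50 log units; beyond the scatter). The estimate for compound 4 is 3500 nM, with an expected range of 1500 nM to 8500 nM.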

Compound 4, half-maximal inhibitory concentration: 7880 nM
Estimate against measurement, compound 4: 2.3-fold (0.35 log units) below, and the stated range covers the measured number.
By their numbers in this assay, from the lowest: compound 1; then compounds 2, 4 and 3 (each within the scatter of the next).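

In this assay, methoxy does not return the series to the level of compound 1: a 4.0-fold higher number from compound 1 to compound 4 (0.60 log units; beyond the scatter) stands beyond the scatter, while a 1.4-fold lower number from compound 3 to compound 4 (0.15 log units; within the scatter) stands within it, so at this place, on a saturated chain carbon, two bonds along the chain from a sulfur, losing the hydrogen-bond donor of acetamido leaves the number unmoved. With a 1.0-fold higher number from compound 2 to compound 4 (0.00 log units; within the scatter) also within the scatter, the (2-methoxyethyl)sulfanyl and ethylamino groups cannot be told apart here. Nothing at hand speaks to the cause of these steps. From the compounds shown here alone, whether an amine, a carboxylic acid or a longer chain at this place would match compound 1 or compound 4 stays open.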